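A Chloropyridine Amide Replaces a Methylthiazole Amide

A few compounds are considered here, and "the series" means these few. Any claim that something is new, unique, unknown or untested is made for them only; others in the source may bear on it.

Compound 1 `O=C(Nc1ccc(Cl)c(-c2nnc3c(Cl)cccn23)c1)c1ccc(F)cc1Cl`: in a functional assay on T47D cells (Homo sapiens) for antiproliferative activity, read by MTT assay, with a stated time of 72 h (a higher number here means a weaker inhibitor, a lower number a stronger inhibitor), compound 1 gives > 100000 nM, a limit of the assay rather than a number.
Compound 2 `Cc1nc(C(=O)Nc2ccc(Cl)c(-c3nnc4c(Cl)cccn34)c2)cs1`: in this assay compound 2 gives > 100000 nM, again a limit of the assay.
Compound 3 `O=C(Nc1ccc(Cl)c(-c2nnc3c(Cl)cccn23)c1)c1ccc(C(F)(F)F)cc1F`: in this assay compound 3 gives 70800 nM.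

All three measured compounds share one core and differ only in the group attached to the carbonyl carbon of the amide. Compound 2 stands at the limit of this assay (the limit of > 100000 nM in this assay, at which 2 of the 3 values shown sit). Compound 3 alone gives a number, and a weak one. Among the measured compounds shown here, the only single-point step among the measured compounds, a step that the two limits leave unreadable from compound 1 to compound 2, is not readable, both of its ends being limits.

Compound 4 `O=C(Nc1ccc(Cl)c(-c2nnc3c(Cl)cccn23)c1)c1cccnc1Cl` differs from compound 2 by 2-chloropyridin-3-yl in place of 2-methyl-1,3-thiazol-4-yl on a carbonyl carbon. For the measured compounds named here, no measured step bears directly on this change, and the one step available gives no size. What the numbers do show is that every measured variation of the amide group leaves the compound at or near the limit of this assay. Compound 4 is expected to behave the same way, at about 100000 nM, within 40000 nM to 300000 nM, and quite possibly as a limit once more. The expected step of a number no higher from compound 2 to compound 4 (the limit leaves the size open) is thus none beyond the scatter.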

Compound 4, half-maximal inhibitory concentration: > 100000 nM
Compound 4 gave a limit, no number; the forecaster's own chance of this, stated with the estimate: 60%; the middle value lies on the limit itself.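

In this assay compound 4 gives > 100000 nM, a limit of the assay and not a number. The steps from compound 2 and from compound 1 to compound 4 cannot be read, as both ends of each are limits. The compounds shown leave open how the amide groups of compound 1, compound 2 and compound 4 rank against one another.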